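The source may report more compounds than this note shows. Statements on the series, on what has been measured and on what is new or still open speak of the compounds shown alone.

Compounds measured in a functional assay on SK-MEL-5 cells (Homo sapiens) for inhibition, read by sulforhodamine B assay, with a stated time of 48 h, tested at 10 uM; a lower number here means less inhibition, a higher number more inhibition at the concentration tested (going by the name of the read-out):
- compound 1, `COc1ccc(-c2cn3ccnc3c(-c3ccc4ncn(C5CCCCC5)c4c3)n2)cc1`, gives 92.3%
- compound 2, `Fc1ccc(-c2cn3ccnc3c(-c3ccc4ncn(C5CCCCC5)c4c3)n2)cc1`, gives 7.36%
- compound 3, `Clc1ccc(-c2cn3ccnc3c(-c3ccc4ncn(C5CCCCC5)c4c3)n2)cc1`, gives 12.4%

Compound 2 gives the lowest of the three numbers in this assay. Its nearest neighbour is compound 3, reached by a number 5 percentage points higher from compound 2 to compound 3 (within the scatter); the furthest is compound 1, from which compound 2 is separated by a number 84.9 percentage points lower from compound 1 to compound 2 (beyond the scatter). The step from compound 1 to compound 3 is of the same kind, a number 79.9 percentage points lower from compound 1 to compound 3 (beyond the scatter).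

The next compound, compound 4, `FC(F)(F)c1cccc(-c2cn3ccnc3c(-c3ccc4ncn(C5CCCCC5)c4c3)n2)c1`, has not yet been measured. It differs from compound 2 in one place: 3-(trifluoromethyl)phenyl in place of 4-fluorophenyl on an aromatic carbon. Going by the values given here, no measured step shows a trifluoromethyl group, nor a substituent in this position of the phenyl ring. What the measured steps do show is that the two halogen-bearing compounds, compound 2 and compound 3, sit close together and far below compound 1. On that basis compound 4 is expected to remain in the low region, with a step of a number 7.6 percentage points higher from compound 2 to compound 4 (within the scatter) in this assay. The estimate for compound 4 is 15%, between 0% and 45%.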

Compound 4, a percentage reported as inhibition, at one concentration (the size of the read-out at that concentration, not a potency): 4.32%
Estimate against measurement, compound 4: 10.7 percentage points above; the range from low to high includes it.
By their numbers in this assay, from the lowest: compounds 4, 2 and 3 (each within the scatter of the next); then compound 1.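

In this assay, the change to 3-(trifluoromethyl)phenyl at this aromatic carbon gives a number 3 percentage points lower from compound 2 to compound 4 (within the scatter) and a number 8.1 percentage points lower from compound 3 to compound 4 (within the scatter), so a substituent with a different group and a different place on the phenyl ring falls in with the two halogen-bearing compounds and does not open a new level. Set against the methoxy-bearing compound, the same change gives a number 88 percentage points lower from compound 1 to compound 4 (beyond the scatter), which leaves 4-methoxyphenyl alone at the high end among four aryl groups at this position. Nothing available explains why the methoxy-bearing compound stands apart.

As far as these compounds go, whether that high number belongs to the methoxy group itself or to its place on the phenyl ring stays open. From the compounds shown here alone, what a hydroxyl, an ethoxy group or an amine on that ring would give also stays open.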